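Compound 3 to Compound 4: A Larger Aromatic Group

This account rests on a few compounds, and the source may have more. Where it says the series, first, only, none or still open, it means among the compounds named here.

Compound 1 `COc1ccc(-c2cc(/N=C3/NC(=O)CS3)cs2)cc1` gives in a functional assay on MDA-MB-231 cells (Homo sapiens) for cytotoxicity, read by MTT assay, with a stated time of 72 h (on this read-out higher numbers stand for weaker inhibition and lower numbers for stronger inhibition), a limit of > 50000 nM.
Compound 2 `O=C1CS/C(=N\c2csc(-c3ccc(Cl)cc3)c2)N1` gives in this assay a limit of > 50000 nM.
Compound 3 `Cc1ccc(/C=C2\S/C(=N\c3csc(-c4ccc(Cl)cc4)c3)NC2=O)cc1` gives in this assay 900 nM.

Among the compounds with values here, compound 3 holds the only number among the three values; the values of compound 1 and compound 2 are limits, as the limit of > 50000 nM in this assay, at which 2 of the 3 values shown sit, states. Within the data shown here, the one measured step, a step that the two limits leave unreadable from compound 1 to compound 2, runs between two limits and its size cannot be read. The change to compound 4 `O=C1N/C(=N/c2csc(-c3ccc(Cl)cc3)c2)S/C1=C\c1ccc2ccccc2c1` is naphthalen-2-yl in place of 4-methylphenyl on a double-bonded chain carbon bound to a double-bonded ring carbon. Among the measured compounds shown here, none of the measured compounds varies at this place, and the only measured step concerns a different part of the molecule and is itself unreadable, so no measured step bears on the change from compound 3 to compound 4. Compound 3 is therefore the only anchor, and a step of no readable size beyond the scatter is expected in this assay, with wide uncertainty in either direction. On that basis compound 4 is expected to give 700 nM in this assay, within 200 nM to 2500 nM. This expectation means a step of a 1.3-fold lower number from compound 3 to compound 4 (0.11 log units; within the scatter).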

Compound 4, half-maximal inhibitory concentration: 1800 nM
Compound 4: middle estimate off by 2.6-fold (0.41 log units), on the low side; low and high end bracket the measured number.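

In this assay, within the data shown here, naphthalen-2-yl in place of 4-methylphenyl gives a 2.0-fold higher number from compound 3 to compound 4 (0.30 log units; within the scatter), and this is the first step that can be read. It shows that, on a double-bonded chain carbon bound to a double-bonded ring carbon, two six-membered aromatic rings of carbon only can stand in place of one while the number stays within the scatter of that of compound 3, so the added ring leaves no readable mark on this read-out. Nothing in the information available accounts for the outcome at this place.

The compounds shown leave open whether a group other than a plain carbon aromatic ring, such as a pyridine ring, a carboxylic acid or a dimethylamino substituent on the phenyl ring, would hold a number of this order at the same place. Among these compounds, they also leave open how methoxy and chloro on the aromatic carbon compare once such a group is present, since the only step between those two substituents runs between two limits and cannot be read.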